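From Chloro to Hydroxy at the Assay Limit

A few compounds are considered here, and "the series" means these few. Any claim that something is new, unique, unknown or untested is made for them only; others in the source may bear on it.

Of the compounds shown here, two have so far been tested in a functional assay on PSN1 cells (Homo sapiens) for antiproliferative activity; on this read-out higher numbers stand for weaker inhibition and lower numbers for stronger inhibition: compound 1 `C/C(=C\Cc1ccc(C(N)=O)[nH]1)CCC(=O)O` and compound 2 `C/C(=C\Cn1cnc2c(Cl)ncnc21)CCC(=O)O`. Compound 1 gives > 100000 nM, which is a limit of the assay and not a number. Compound 2 gives > 100000 nM, which is likewise a limit. Compound 2 therefore stands at the limit of > 100000 nM in this assay, at which 2 of the 2 values shown sit, and no number places it more exactly.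

The next compound is compound 3 `C/C(=C\Cn1cnc2c(O)ncnc21)CCC(=O)O`, which differs from compound 2 in a single group: hydroxy in place of chloro on an aromatic carbon. Hydroxy takes the place of chloro on an aromatic carbon of a six-membered aromatic ring with 2 nitrogen, part of a fused or bridged system of two rings. Going by the values given here, no measured pair of compounds differs in one place, so the data give no direct guide to the size of this change in this assay. This expectation therefore rests on compound 2, whose > 100000 nM is a limit. The expected step of a number no higher from compound 2 to compound 3 (the limit leaves the size open) is no larger than the usual scatter and has no expected direction. For compound 3 the estimated value is 100000 nM, with an expected range from 40000 nM to 250000 nM.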

Compound 3, half-maximal inhibitory concentration: > 100000 nM
Compound 3 ended at the assay's limit; the forecaster's own chance of this, stated with the estimate: 85%; the middle value lies on the limit itself.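

Compound 2 and compound 3 both end at a limit of the assay and not at a number, so the exchange of chloro for hydroxy gives no step that can be read: the limit of > 100000 nM in this assay, at which 3 of the 3 values shown sit.

The compounds shown leave open how strongly, if at all, any of them acts in this assay, and whether hydroxy and chloro differ there.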